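Adding 1,2-dihydroxyethyl to compound 3

A few compounds are considered here, and "the series" means these few. Any claim that something is new, unique, unknown or untested is made for them only; others in the source may bear on it.

Compound 1 (`COc1ccc2c(c1O)CCCC(CCC#N)=C2c1cc(OC)c(OC)c(OC)c1`) gives > 320 mL.min-1.g-1 as a limit of the assay
Compound 2 (`COc1ccc2c(c1O)CCCC(CCCC#N)=C2c1cc(OC)c(OC)c(OC)c1`) gives 239 mL.min-1.g-1
Compound 3 (`COc1ccc2c(c1O)CCCC(C)=C2c1cc(OC)c(OC)c(OC)c1`) gives 108 mL.min-1.g-1

In an ADME assay (liver) for metabolic stability, with Liver microsome (Homo sapiens) as the target, using microsomes, tested at 1 uM (on this read-out higher numbers stand for fast clearance and lower numbers for slow clearance), compound 3 has the lowest number of these three. Compound 4 (`COc1ccc2c(c1O)CCCC(CC(O)CO)=C2c1cc(OC)c(OC)c(OC)c1`) carries 1,2-dihydroxyethyl in place of hydrogen on a saturated chain carbon bound to a double-bonded ring carbon. Among the compounds with values here, two measured steps bear on this. One is a 2.2-fold lower number from compound 2 to compound 3 (0.34 log units; beyond the scatter) and hints at a rise when a chain is added. The other is an at least 2.9-fold lower number from compound 1 to compound 3 (0.47 log units; beyond the scatter) and rests on the limit (the limit of > 320 mL.min-1.g-1 in this assay, at which 1 of the 3 values shown sits). Both removed chains end in a nitrile, so they carry over only loosely to a chain with hydroxyl groups. The expected step is a 1.5-fold higher number from compound 3 to compound 4 (0.17 log units; within the scatter) and is not expected to stand clearly beyond the scatter. Compound 4 is estimated at 160 mL.min-1.g-1 (70 mL.min-1.g-1 to 320 mL.min-1.g-1).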

Compound 4, intrinsic clearance in microsomes: 66.3 mL.min-1.g-1
Compound 4: middle estimate off by 2.4-fold (0.38 log units), on the high side, outside the stated range (below it).
By their numbers in this assay, from the lowest: compounds 4 and 3 (each within the scatter of the next); then compound 2. At a limit, above all of these: compound 1.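

In this assay, a chain added at this position need not raise the number, as the nitrile chains had hinted: 1,2-dihydroxyethyl in place of hydrogen gives a 1.6-fold lower number from compound 3 to compound 4 (0.21 log units; within the scatter). The end of the chain counts here: 1,2-dihydroxyethyl in place of 2-cyanoethyl gives a 3.6-fold lower number from compound 2 to compound 4 (0.56 log units; beyond the scatter), and in place of cyanomethyl it gives an at least 4.8-fold lower number from compound 1 to compound 4 (0.68 log units; beyond the scatter). That last step starts from a limit for compound 1: the limit of > 320 mL.min-1.g-1 in this assay, at which 1 of the 4 values shown sits.

As far as these compounds go, whether an amine or a carboxylic acid at the end of this chain would keep the number this low remains open. So does the outcome for a longer chain carrying hydroxyl groups.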